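The compounds below may be only part of what the source reports. "The series", "measured", "known", "first", "only" and "open" are said of these compounds alone.

Among the measured compounds shown here, compound 2 `CNC(=O)NC[C@H]1O[C@@H](n2cnc3c(NC(=O)Nc4ccccc4)ncnc32)[C@H](O[Si](C)(C)C(C)(C)C)[C@@H]1CC(=O)N(C)OC` is one of two compounds so far tested in a functional assay on ACHN cells (Homo sapiens) for antiproliferative activity; on this read-out higher numbers stand for weaker inhibition of growth and lower numbers for stronger inhibition of growth. In this assay compound 2 gives 14.4 nM, the higher of the two numbers, and the gap to the other lies beyond the usual scatter. Compound 3 `CCOC(=O)C[C@H]1[C@@H](O[Si](C)(C)C(C)(C)C)[C@H](n2cnc3c(NC(=O)Nc4ccccc4)ncnc32)O[C@@H]1CNC(=O)NC` has not yet been measured. It differs from compound 2 in one place: ethoxy in place of methoxy(methyl)amino on a carbonyl carbon. Compound 1 `CCOC(=O)C[C@H]1[C@@H](O[Si](C)(C)C(C)(C)C)[C@H](n2cnc3c(NC(=O)Nc4ccccc4)ncnc32)O[C@@H]1COC(=O)NC`, which also carries the ethoxycarbonyl group, gives the lower number, 5.92 nM. On that basis a modest fall is expected, a step of a 1.8-fold lower number from compound 2 to compound 3 (0.26 log units; within the scatter). Compound 3 is therefore estimated at 8 nM, within 3 nM to 22 nM.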

Compound 3, concentration for 50% growth inhibition: 8.55 nM
For compound 3 the middle estimate is 1.1-fold (0.03 log units) below the measured one; low and high end bracket the measured number.
By their numbers in this assay, from the lowest: compounds 1, 3 and 2 (each within the scatter of the next, the first and the last beyond it).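

In this assay, putting ethoxy in place of methoxy(methyl)amino on a carbonyl carbon gives a 1.7-fold lower number from compound 2 to compound 3 (0.23 log units; within the scatter) and so leaves the number within the scatter at this position. Likewise, (methylcarbamoyl)amino in place of (methylcarbamoyl)oxy gives a 1.4-fold higher number from compound 1 to compound 3 (0.16 log units; within the scatter) and shows that this second single change also cannot be told from the scatter. No measured evidence here explains either result. As far as these compounds go, whether an amine or a carboxylic acid on that carbonyl carbon would keep the number in this range remains open.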